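This account rests on a few compounds, and the source may have more. Where it says the series, first, only, none or still open, it means among the compounds named here.

Measured in an ADME assay on BJ cells (Homo sapiens) for cytotoxicity, with a stated time of 72 h; on this read-out higher numbers stand for an effect only at larger amounts of compound and lower numbers for an effect already at smaller amounts:
- compound 1 `Cc1cc(NC(=O)Nc2ccc(C(C)(C)C)cc2)c2ccccc2n1` gives 20000 nM
- compound 2 `CC(=O)c1ccc(NC(=O)Nc2cc(C)nc3ccccc23)cc1` gives 22000 nM
- compound 3 `Cc1cc(NC(=O)Nc2ccc(N)cc2)c2ccccc2n1` gives > 25000 nM

For compound 3 the entry > 25000 nM is a limit of the assay and not a number. Compound 3 thus stands at the limit of > 25000 nM in this assay, at which 1 of the 3 values shown sits.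

Compound 4 `Cc1cc(NC(=O)Nc2ccc(Cl)cc2)c2ccccc2n1` changes the same substituent: chloro in place of amino on an aromatic carbon, para to a large group.

For the measured compounds named here, three measured steps bear on this place: a 1.1-fold higher number from compound 1 to compound 2 (0.04 log units; within the scatter), an at least 1.2-fold higher number from compound 1 to compound 3 (0.09 log units; that floor lies within the scatter) and an at least 1.1-fold higher number from compound 2 to compound 3 (0.05 log units; that floor lies within the scatter). All three lie within the scatter, and the last two are known only as floors. Tert-butyl, acetyl and amino have therefore shown no separation here, and no step beyond the scatter is expected in this assay for chloro. Any expected movement would be small and towards a lower number, and the estimated step is an at least 1.2-fold lower number from compound 3 to compound 4 (0.09 log units; that floor lies within the scatter). Compound 4 is expected at 20000 nM, with an estimated range of 10000 nM to 32000 nM.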

Compound 4, half-maximal effective concentration: > 25000 nM
Compound 4 ended at the assay's limit; the forecaster's own chance of this, stated with the estimate: 35%; at least 1.2-fold (0.09 log units) between middle value and limit.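

Compound 4, with chloro on an aromatic carbon para to a large group, joins compound 3 at a limit of the read-out in this assay, so two different groups at this position now give a limit entry: the limit of > 25000 nM in this assay, at which 2 of the 4 values shown sit.

Amino's hydrogen-bond donor and acceptor are gone in compound 4, yet the entry stays at the limit, and the step between compound 3 and compound 4 cannot be read. Against the other two groups, the readable steps are an at least 1.1-fold higher number from compound 2 to compound 4 (0.05 log units; that floor lies within the scatter) and an at least 1.2-fold higher number from compound 1 to compound 4 (0.09 log units; that floor lies within the scatter), so chloro shows no separation from acetyl or tert-butyl.

Going by these compounds, whether compound 3 and compound 4 differ at all stays open, as does whether any group at this position gives a step beyond the scatter. A carboxylic acid or a dimethylamino group here would extend the comparison to groups unlike those shown.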